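Methyl added to the anilino part: expected read-out

A few compounds are considered here, and "the series" means these few. Any claim that something is new, unique, unknown or untested is made for them only; others in the source may bear on it.

For the measured compounds named here, compound 2 `Cc1ccc(C(=O)c2sc(Nc3ccccc3)c(C(=O)O)c2C)cc1` is the one member of the series with a numerical read-out: in a functional assay, with a stated time of 150 min, tested at 30 ug/mL (on this read-out lower numbers stand for a weaker effect and higher numbers for a stronger effect at the one concentration tested), compound 2 gives 5.13%, a weak effect at the single concentration. Compound 1 `COc1ccc(C(=O)c2sc(Nc3ccc(C)cc3)c(C(=O)O)c2C)cc1` carries the same core with a methoxy group on the benzoyl part and a methyl on the anilino part; in this assay compound 1 gives "not active" (no number reported), reported without a number. Going by the values given here, no pair of measured compounds differs in only one place, so no measured step is available.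

Compound 3 `Cc1ccc(Nc2sc(C(=O)c3ccc(C)cc3)c(C)c2C(=O)O)cc1` differs from compound 2 by methyl in place of hydrogen on an aromatic carbon. The step in this assay from compound 2 to compound 3 is expected to be small, not beyond the scatter in either direction, given that compound 2 gives 5.13% and compound 1, also bearing the methyl on the anilino part, is reported as "not active" (no number reported). Compound 3 is therefore estimated at 5%, within 0% to 15%, the estimated step being a number 0.1 percentage points lower from compound 2 to compound 3 (within the scatter).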

Compound 3, a percentage reported as activity, at one concentration (the size of the read-out at that concentration, not a potency): "not active" (no number reported)
No number was reported for compound 3, and the estimate cannot be compared.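

For the compounds shown here, compound 3 is reported in this assay as "not active" (no number reported) and so no step from compound 2 can be read. The compounds shown leave open whether methyl in place of hydrogen on the anilino part changes the read-out at all. No evidence bears on this result.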